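This account rests on a few compounds, and the source may have more. Where it says the series, first, only, none or still open, it means among the compounds named here.

Measured compounds in a functional assay on U-373MG ATCC cells (Homo sapiens) for inhibition, read by colorimetric assay and MTT assay, with a stated time of 72 h; a lower number here means a stronger inhibitor, a higher number a weaker inhibitor:

- compound 1, `COc1ccc2c(c1)-c1cnc(n1C)OCCCCCCCCO2`, gives 63000 nM
- compound 2, `Cn1c2cnc1OCCCCCCCCOc1ccc(F)cc1-2`, gives 73000 nM
- compound 3, `C=CCCCCOc1ccc(OC)cc1-c1cnc(OCCC=C)n1C`, gives 67000 nM

Compound 1 and compound 2 share a core; the change between them is fluoro in place of methoxy on an aromatic carbon and the step it made is a 1.2-fold higher number from compound 1 to compound 2 (0.06 log units; within the scatter). Compound 3 carries an open core in place of the macrocycle of compound 1; the difference between the two cores is not broken down here. What the two values show is that compound 3 and compound 1 lie within the scatter of each other in this assay.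

Compound 4, `C=CCCCCOc1ccc(F)cc1-c1cnc(OCCC=C)n1C`, has not been measured. It differs from compound 3 by fluoro in place of methoxy on an aromatic carbon. For the measured compounds named here, this is the same kind of change as the one from compound 1 to compound 2, but not the same: there the aromatic carbon is part of a fused or bridged system of three rings, meta to a fused ring and para to a fused ring, whereas here it is meta to a large group and para to a (hex-5-en-1-yl)oxy group. Because the measured instance gave a 1.2-fold higher number from compound 1 to compound 2 (0.06 log units; within the scatter), the expected step from compound 3 to compound 4 is of about the same small size, a 1.2-fold higher number from compound 3 to compound 4 (0.07 log units; within the scatter). Compound 4 is therefore estimated at 78000 nM in this assay, with a range of 40000 nM to 150000 nM expected.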

Compound 4, half-maximal inhibitory concentration: 73000 nM
Compound 4: middle estimate off by 1.1-fold (0.03 log units), on the high side; the measured number falls inside the stated range.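

In this assay fluoro in place of methoxy on the open core gives a 1.1-fold higher number from compound 3 to compound 4 (0.04 log units; within the scatter) and so leaves the number where it was, as far as this assay can tell. The same change on the macrocycle of compound 1 and on the open core of compound 3 gives steps that do not differ: the same change on two cores in this assay, a 1.2-fold higher number (0.06 log units; within the scatter) from compound 1 to compound 2 and a 1.1-fold higher number (0.04 log units; within the scatter) from compound 3 to compound 4, 1.1-fold (0.03 log units) apart, within the scatter of two such steps. Since neither step lies beyond the scatter, this is agreement between two steps too small to read as an effect, not the transfer of a measured gain or loss, and it shows nothing about cores other than these two or about any other assay.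

From the compounds shown here alone, at this aromatic carbon only methoxy and fluoro are present, so it remains open whether an amine, a carboxylic acid or a longer alkoxy chain there would give a step beyond the scatter, and whether such a step would carry from one core to the other. Also open, going by these compounds, is what a shorter chain in place of the (hex-5-en-1-yl)oxy group, or a longer or shorter chain closing the macrocycle, would do to the number.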